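Moving the methylpyrazole attachment point on an inactive core

A few compounds are considered here, and "the series" means these few. Any claim that something is new, unique, unknown or untested is made for them only; others in the source may bear on it.

This account follows a single change on the core of compound 1 `Cn1ccc(-c2cccc3c2CCC3c2ncc[nH]2)n1` and asks what it may do in a functional assay on CHO cells for agonist activity at Alpha-1B adrenergic receptor (Homo sapiens), read by FLIPR and calcium flux; a lower number here means that less compound is needed, a higher number that more compound is needed for the effect. Compound 1 reaches only the limit of this assay, > 10000 nM, and so has no number of its own. The same holds for compound 2 `Cc1c(OCC2=NCCN2)ccc(Cl)c1NS(C)(=O)=O`, which in this assay sits at the limit > 10000 nM. Compound 3 `CS(=O)(=O)Nc1c(Cl)ccc2c1CCCC2c1ncc[nH]1` likewise gives only the limit > 10000 nM in this assay. Every value shown is therefore a limit rather than a number: the limit of > 10000 nM in this assay, at which 3 of the 3 values shown sit. No pair among these three differs in one place, so no measured step exists to lean on.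

Compound 4 `Cn1cc(-c2cccc3c2CCC3c2ncc[nH]2)cn1` is the compound not yet measured. It differs from compound 1 in one place: 1-methyl-1H-pyrazol-4-yl in place of 1-methyl-1H-pyrazol-3-yl on an aromatic carbon, ortho to a fused ring and meta to a fused ring.

With all three measured compounds at the limit, no direction can be read from the data. The step that the limit leaves unreadable from compound 1 to compound 4 is expected to be none beyond the scatter, and the result most likely remains a limit. Compound 4 is therefore expected to give about 15000 nM, in a range from 4000 nM to 60000 nM.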

Compound 4, half-maximal effective concentration: > 10000 nM
Compound 4 gave a limit, no number; the forecaster's own chance of this, stated with the estimate: 80%; the middle value is on the limit's open side.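

Compound 4 joins compound 1 at the limit, so no step can be read between them, and the exchange of 1-methyl-1H-pyrazol-3-yl for 1-methyl-1H-pyrazol-4-yl shows no readable size: the limit of > 10000 nM in this assay, at which 4 of the 4 values shown sit. The compounds shown leave open how far each lies from that limit and whether these two groups differ at all.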